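Two Aryl Ureas Judged for Toxicity to Melanoma Cells

The compounds below may be only part of what the source reports. "The series", "measured", "known", "first", "only" and "open" are said of these compounds alone.

Compound 1, `O=C(Nc1cccc(-n2cc(-c3ccncc3)c(-c3ccc(Cl)c(O)c3)n2)c1)Nc1cccc(C(F)(F)F)c1`: in a functional assay on Malme-3M cells (Homo sapiens) for inhibition, read by sulforhodamine B assay, with a stated time of 48 h (on this read-out lower numbers stand for higher toxicity in this test and higher numbers for lower toxicity in this test), compound 1 gives > 32500 nM, which is a limit of the assay and not a number.
Compound 2, `COc1cc(-c2nn(-c3cccc(NC(=O)Nc4ccc(Cl)c(Cl)c4)c3)cc2-c2ccncc2)ccc1Cl`: in this assay compound 2 gives > 50000 nM, again only a limit.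
Compound 3, `O=C(Nc1cccc(-n2cc(-c3ccncc3)c(-c3ccc(Cl)c(O)c3)n2)c1)Nc1ccc(Cl)c(Cl)c1`: in this assay compound 3 gives > 32500 nM, again only a limit.

Compound 4, `COc1cc(-c2nn(-c3cccc(NC(=O)Nc4cccc(C(F)(F)F)c4)c3)cc2-c2ccncc2)ccc1Cl`, has not yet been measured in this assay. It differs from compound 2 by 3-(trifluoromethyl)phenyl in place of 3,4-dichlorophenyl on an amide-type nitrogen. Among the measured compounds the same change occurs once, from compound 3 to compound 1, (3-(trifluoromethyl)phenyl in place of 3,4-dichlorophenyl on an amide-type nitrogen), where it made a step that the two limits leave unreadable from compound 3 to compound 1. Both ends of that step sit at the limit of > 32500 nM in this assay, at which 2 of the 3 values shown sit, so its size cannot be read. The cores of compound 2 and compound 3 differ by methyl in place of hydrogen on an oxygen on an aromatic ring, and the step that the two limits leave unreadable from compound 2 to compound 3 is equally unreadable because compound 2 sits at the limit of > 50000 nM in this assay, at which 1 of the 3 values shown sits.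

No measured number therefore constrains what the change from compound 2 to compound 4 will do. The step is expected to be a step that the limit leaves unreadable from compound 2 to compound 4, an expectation that rests on the pair of compound 3 and compound 1 both remaining at the limit of > 32500 nM in this assay, at which 2 of the 3 values shown sit, after the same change. Compound 4 is expected to give 60000 nM in this assay, most probably reported again only as a limit. For compound 4 the expected range runs from 30000 nM to 150000 nM.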

Compound 4, concentration lethal to 50% of the cells: 33900 nM
The estimate for compound 4 lay 1.8-fold (0.25 log units) above the measured number, within the range that was stated.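

In this assay, 3-(trifluoromethyl)phenyl in place of 3,4-dichlorophenyl on the amide-type nitrogen of the core of compound 2 gives an at least 1.4-fold lower number from compound 2 to compound 4 (0.16 log units; that floor lies within the scatter), so what can be read of this change does not go beyond the usual scatter of repeated measurements. From the compounds shown here alone, compound 2 has only > 50000 nM, which is a limit of the assay and not a number, so the true size of the step stays unknown: it may be small or much larger, and a real rise in toxicity is not established. The same change on the core of compound 3 leads to compound 1, and neither that step nor any other step here apart from the one above can be read, so nothing shows whether the change carries from one core to the other: the limit of > 32500 nM in this assay, at which 2 of the 4 values shown sit.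

The compounds shown leave open whether a hydrogen or a methyl on the oxygen alters what the change from 3,4-dichlorophenyl to 3-(trifluoromethyl)phenyl does, a question that would need a measured number at both ends of each step. They also leave open how an amine or a carboxylic acid on that phenyl ring, or a longer chain in place of the methyl on the oxygen, would read in this assay.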